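The compounds below may be only part of what the source reports. "The series", "measured", "known", "first", "only" and "open" are said of these compounds alone.

Measured compounds:
compound 1, `CCCCSC1=N[C@@H](C(=O)OC)[C@@H]2C(=O)N(c3ccccc3)C(=O)[C@H]12`, gives 82%;
compound 2, `CCSC1=N[C@H](C(=O)OC)[C@@H]2C(=O)N(c3ccccc3)C(=O)[C@H]12`, gives 89%;
compound 3, `COC(=O)[C@H]1N=C(SCc2ccccc2)[C@H]2C(=O)N(c3ccccc3)C(=O)[C@H]21`, gives 76%.

All three were tested in a functional assay for inhibition, tested at 100 uM; a higher number here means more inhibition at the concentration tested (going by the name of the read-out), a lower number less inhibition. Compound 1 stands second highest of the three numbers, but its gap to compound 3 and its gap to compound 2 both lie within the usual scatter of this kind of measurement, so no order among the three can be read from them. Within the data shown here, the one step that reaches beyond the scatter is a number 13 percentage points lower from compound 2 to compound 3 (beyond the scatter), a modest change for phenyl in place of methyl on a saturated chain carbon bound to a sulfur.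

Compound 4, `COC(=O)[C@@H]1N=C(SC(C)C)[C@H]2C(=O)N(c3ccccc3)C(=O)[C@H]21`, has not yet been measured. It differs from compound 1 by isopropyl in place of butyl on a sulfur. The measured step bears on it only loosely, as it concerns a different change on the same sulfur, and the three chains seen so far give numbers that fall close together. In this assay no step beyond the scatter is therefore expected. Compound 4 is estimated at 84%, between 72% and 94%. The expected step is a number 2 percentage points higher from compound 1 to compound 4 (within the scatter).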

Compound 4, a percentage reported as inhibition, at one concentration (the size of the read-out at that concentration, not a potency): 89%
Compound 4: middle estimate off by 5 percentage points, on the low side, within the range that was stated.
By their numbers in this assay, from the lowest: compounds 3, 1, 2 and 4 (each within the scatter of the next, the first and the last beyond it).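

Replacing butyl with isopropyl on the sulfur gives a number 7 percentage points higher from compound 1 to compound 4 (within the scatter) in this assay, so this exchange of one chain for the other produces no difference that can be told apart from ordinary scatter. The change at this sulfur that does reach beyond the scatter remains phenyl in place of methyl, which gives a number 13 percentage points lower from compound 2 to compound 3 (beyond the scatter) and shows that not every change here is equally quiet. No supporting measurement is available to explain why the numbers for the butyl and isopropyl compounds stay so close.

All the chains shown on this sulfur contain only carbon and hydrogen, so the effect of an amine or a carboxylic acid at the end of the chain remains open. As far as these compounds go, how a much longer chain, such as octyl, would compare also remains unknown.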